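A few compounds are considered here, and "the series" means these few. Any claim that something is new, unique, unknown or untested is made for them only; others in the source may bear on it.

Compound 1 `O=C(OC1CCC(CN2CCN(c3cc(=O)c4cc(C(F)(F)F)cc([N+](=O)[O-])c4s3)CC2)CC1)c1ccccc1`: > 64 ug/mL, a limit of the assay.
Compound 2 `O=C(OC1CCC(CN2CCN(c3cc(=O)c4cc(C(F)(F)F)cc([N+](=O)[O-])c4s3)CC2)CC1)C1CCC1`: > 64 ug/mL, a limit of the assay.

In an ADME assay on Vero cells (Chlorocebus sabaeus) for cytotoxicity, read by MTT assay, with a stated time of 48 h (on this read-out higher numbers stand for weaker inhibition and lower numbers for stronger inhibition), compound 1 gives only the limit > 64 ug/mL, not a number. Compound 2 likewise stops at the limit > 64 ug/mL. Going by the values given here, the one measured step, a step that the two limits leave unreadable from compound 1 to compound 2, is thus of unknown size; all that is known is the limit of > 64 ug/mL in this assay, at which 2 of the 2 values shown sit. Compound 3 `COc1cccc(C(=O)OC2CCC(CN3CCN(c4cc(=O)c5cc(C(F)(F)F)cc([N+](=O)[O-])c5s4)CC3)CC2)c1` differs from compound 1 by methoxy in place of hydrogen on an aromatic carbon. Among the compounds with values here, no measured step bears on this change, so no movement beyond the scatter is foreseen in this assay. Compound 3 is therefore expected to give about 80 ug/mL, within 40 ug/mL to 160 ug/mL, an expected step that the limit leaves unreadable from compound 1 to compound 3.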

Compound 3, half-maximal inhibitory concentration: > 64 ug/mL
Compound 3 ended at the assay's limit; the forecaster's own chance of this, stated with the estimate: 80%; the middle value does not contradict the limit.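

Compound 1, compound 2 and compound 3 each end at a limit rather than a number, so no step among them can be read: the limit of > 64 ug/mL in this assay, at which 3 of the 3 values shown sit.

The compounds shown leave open whether phenyl, cyclobutyl and 3-methoxyphenyl differ at all in this assay.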